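Benzazole piperazine oxadiazole thioethers: methyl to bromo step

The source may hold more compounds than are shown below. What is called first, only, known or untested is meant among the compounds shown, and "the series" means these compounds.

Three compounds of the series carry numbers in a functional assay on A549 cells (Homo sapiens) for inhibition, read by MTT assay, with a stated time of 72 h; a higher number here means a weaker inhibitor, a lower number a stronger inhibitor. Compound 1 `Cc1ccc(-c2nnc(SCCCN3CCN(c4nc5ccccc5o4)CC3)o2)cc1` gives 106000 nM. Compound 2 `COc1ccc(-c2nnc(SCCCN3CCN(c4nc5ccccc5s4)CC3)o2)cc1` gives 90300 nM. Compound 3 `Cc1ccc(-c2nnc(SCCCN3CCN(c4nc5ccccc5s4)CC3)o2)cc1` gives 53900 nM, the lowest of the three, though both of its neighbours lie within the scatter of it: a 2.0-fold lower number from compound 1 to compound 3 (0.29 log units; within the scatter), and a 1.7-fold lower number from compound 2 to compound 3 (0.22 log units; within the scatter). For the measured compounds named here, no step between the three measured compounds leaves the scatter.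

Compound 4 `Brc1ccc(-c2nnc(SCCCN3CCN(c4nc5ccccc5s4)CC3)o2)cc1` has not yet been measured. It differs from compound 3 in one place: bromo in place of methyl on an aromatic carbon. Going by the values given here, no measured step swaps a halogen against a methyl, so nothing bears directly on this change. The nearest comparison is the methyl-for-methoxy exchange, a 1.7-fold lower number from compound 2 to compound 3 (0.22 log units; within the scatter), which stayed within the scatter and suggests that substituents on this six-membered ring move this assay little. The expectation is therefore no step beyond the scatter, a 1.0-fold higher number from compound 3 to compound 4 (0.01 log units; within the scatter), with the direction open. Compound 4 is estimated at 55000 nM, with a range from 20000 nM to 140000 nM in this assay.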

Compound 4, half-maximal inhibitory concentration: 62500 nM
For compound 4 the middle estimate is 1.1-fold (0.06 log units) below the measured one; the range from low to high includes it.
By their numbers in this assay, from the lowest: compounds 3, 4, 2 and 1 (each within the scatter of the next).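

In this assay the change from 4-methylphenyl to 4-bromophenyl gives a 1.2-fold higher number from compound 3 to compound 4 (0.06 log units; within the scatter) and the exchange of methoxy for bromo gives a 1.4-fold lower number from compound 2 to compound 4 (0.16 log units; within the scatter) on the same aromatic carbon. The earlier compounds shown here covered only methyl and methoxy at this place, para to a large group; with a halogen added, all three steps among compounds 2, 3 and 4 stay within the scatter, so none of these three groups can be ranked against another here. Nothing at hand explains this flat result.

As far as these compounds go, whether an amine or a carboxylic acid on this aromatic carbon would leave the scatter stays open, as does the outcome for a longer chain there. Also open, from the compounds shown here alone, is whether bromo behaves the same with 1,3-benzoxazol-2-yl in place of 1,3-benzothiazol-2-yl.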